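Swapping Methoxy for Methyl on the Shared Core

The source may report more compounds than this note shows. Statements on the series, on what has been measured and on what is new or still open speak of the compounds shown alone.

In a physicochemical assay for lipophilicity, measured as octanol-water partition (a higher number here means a more lipophilic compound, a lower number a more polar compound), compound 1 `COc1ccccc1C(=O)O[C@@H]1C[C@H](C)CC[C@H]1C(C)C` gives 4.57 and compound 2 `COc1cccc(C(=O)O[C@@H]2C[C@H](C)CC[C@H]2C(C)C)c1` gives 4.57 as well, so the two stand level. Compound 3 `Cc1cccc(C(=O)O[C@@H]2C[C@H](C)CC[C@H]2C(C)C)c1` differs from compound 2 at one place methyl in place of methoxy on an aromatic carbon with methyl in place of methoxy on an aromatic carbon, meta to a large group. Among the compounds with values here, no measured pair in this set shows such a change, so the expectation rests on judgement alone. The expected move is upward and beyond the scatter, an estimated a number 0.43 log units higher from compound 2 to compound 3 (beyond the scatter) in this assay for this swap. Compound 3 is estimated at 5 with 4.7 to 5.3 as the expected range.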

Compound 3, partition coefficient: 5.29
Compound 3: the middle estimate sits 0.29 log units below what was measured; measured number inside the range.
By their numbers in this assay, from the lowest: compounds 1 and 2 (each within the scatter of the next); then compound 3.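

In this assay, methyl in place of methoxy on an aromatic carbon, meta to a large group, gives a number 0.72 log units higher from compound 2 to compound 3 (beyond the scatter). Compound 1 and compound 2 stood level, so this is the first change shown that moves the read-out beyond the scatter, and it shows that the number responds to what this aromatic carbon carries. Nothing measured here gives a reason for the size of this step. On these data alone, it remains open how an amine, a carboxylic acid or a longer chain on this aromatic carbon would read in this assay, and whether the same swap elsewhere on the shared core gives a step of similar size.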